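A few compounds are considered here, and "the series" means these few. Any claim that something is new, unique, unknown or untested is made for them only; others in the source may bear on it.

Working notes on the series. In a functional assay on cells (Neutrophil, Homo sapiens) for inhibition, with a stated time of 10 min (a lower number here means a stronger inhibitor, a higher number a weaker inhibitor), compound 1 (`O=C(Nc1ccccc1F)N1c2ccnn2CC1c1ccccc1`) gives > 1000 nM, which is a limit and not a number. Compound 2 (`O=C(Nc1ccc(F)cc1)N1c2ccnn2CC1c1ccccc1`) gives > 1000 nM, also a limit. Going by the values given here, the series so far therefore stands at the limit of > 1000 nM in this assay, at which 2 of the 2 values shown sit.

Compound 3 (`NC(=O)c1cnn2c1N(C(=O)Nc1ccccc1F)C(c1ccccc1)C2`) differs from compound 1 in one place, with carbamoyl in place of hydrogen on an aromatic carbon. Among the compounds with values here, the only measured step, a step that the two limits leave unreadable from compound 1 to compound 2, lies at a different place and has no readable size, so it offers no guide to the size of this change. Within the data shown here, no measured step covers the carbamoyl, and another limit remains a real prospect. A modest move toward stronger inhibition in this assay is expected, given as the estimated step that the limit leaves unreadable from compound 1 to compound 3. Compound 3 is estimated at 2000 nM, with an expected range of 400 nM to 10000 nM.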

Compound 3, half-maximal inhibitory concentration: 6.2 nM
Beside the measured number, compound 3's estimate is 320-fold (2.51 log units) above it; the whole stated range lies above it.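

In this assay, going by these compounds alone, carbamoyl in place of hydrogen on an aromatic carbon of the five-membered aromatic ring gives an at least 160-fold lower number from compound 1 to compound 3 (2.20 log units; beyond the scatter), the first readable step and a large one, so this position has a strong hold on the read-out. As far as these compounds go, compound 1 has the value > 1000 nM, which is a limit and not a number, so the true size of the step stays open beyond the bound printed with it. Compound 3 is the only compound shown that gives a number rather than a limit: the limit of > 1000 nM in this assay, at which 2 of the 3 values shown sit.

From the compounds shown here alone, whether the carbamoyl gives a similar step with 4-fluorophenyl on the amide-type nitrogen remains open. Also open, going by these compounds, is whether a nitrile, a carboxylic acid or a methyl ester at the same aromatic carbon would give a step of similar size.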